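Amine ring swap at the propoxy chain terminus

A few compounds are considered here, and "the series" means these few. Any claim that something is new, unique, unknown or untested is made for them only; others in the source may bear on it.

Values in a functional assay on A549 cells (Homo sapiens) for inhibition, read by MTT assay, with a stated time of 72 h (on this read-out lower numbers stand for stronger inhibition and higher numbers for weaker inhibition), so far:
compound 1 `COc1cc2c(Oc3ccc(NC(=O)c4nn(-c5ccccc5OC(F)(F)F)c(=O)cc4C)cc3F)ccnc2cc1OCCCN1CCN(C)CC1` gives 130 nM
compound 2 `COc1cc2c(Oc3ccc(NC(=O)c4nn(-c5cccc(F)c5)c(=O)cc4C)cc3F)ccnc2cc1OCCCN1CCCC1` gives 170 nM
compound 3 `COc1cc2c(Oc3ccc(NC(=O)c4nn(-c5cccc(F)c5)c(=O)cc4C)cc3F)ccnc2cc1OCCCN1CCCCC1` gives 250 nM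

Compound 3 carries the highest of the three numbers, but compound 2, its nearest neighbour, and compound 1, its furthest, both sit within the usual scatter of it, so no order among the three can be read. Within the data shown here, the only step measured at this position, a 1.5-fold higher number from compound 2 to compound 3 (0.17 log units; within the scatter), exchanged one saturated amine ring for a larger one and stayed within the scatter.

Compound 4 `COc1cc2c(Oc3ccc(NC(=O)c4nn(-c5cccc(F)c5)c(=O)cc4C)cc3F)ccnc2cc1OCCCN1CCN(C)CC1` is the next step from compound 3: 4-methylpiperazin-1-yl in place of piperidin-1-yl on a saturated chain carbon, three bonds along the chain from an oxygen on an aromatic ring. Among the measured compounds shown here, this is again a swap of the terminal amine ring on the same saturated chain carbon, and the one measured step of that kind was flat. Compound 1 already carries 4-methylpiperazin-1-yl at this place, paired with a different group elsewhere in the molecule, and in this assay compound 1 gives 130 nM, a number within the scatter of compound 3. The expected step from compound 3 to compound 4 in this assay is therefore a 1.5-fold lower number from compound 3 to compound 4 (0.17 log units; within the scatter), nothing beyond the scatter. The estimate for compound 4 is 170 nM, with a range of 85 nM to 340 nM.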

Compound 4, half-maximal inhibitory concentration: 150 nM
Compound 4: the middle estimate sits 1.1-fold (0.05 log units) above what was measured, within the range that was stated.
By their numbers in this assay, from the lowest: compounds 1, 4, 2 and 3 (each within the scatter of the next).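

With 4-methylpiperazin-1-yl at the end of the chain, three terminal amine rings can now be compared on the 3-fluorophenyl compounds in this assay: a 1.7-fold lower number from compound 3 to compound 4 (0.22 log units; within the scatter) and a 1.1-fold lower number from compound 2 to compound 4 (0.05 log units; within the scatter) join the earlier pyrrolidin-1-yl to piperidin-1-yl step in showing no change beyond the scatter. The result also adds a step at a second place, on an aromatic nitrogen, where 3-fluorophenyl replaces 2-(trifluoromethoxy)phenyl with 4-methylpiperazin-1-yl held fixed: a 1.2-fold higher number from compound 1 to compound 4 (0.06 log units; within the scatter), so across these four compounds neither kind of swap has moved the number beyond the scatter, and none of them goes against this. No independent data bear on these flat steps.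

From the compounds shown here alone, it remains open whether a morpholin-4-yl ring, an open-chain dimethylamino group or a chain longer than 3-(4-methylpiperazin-1-yl)propyl would also stay within the scatter at this place. Also open, going by these compounds, is whether an unsubstituted phenyl on the aromatic nitrogen would do so, and whether the amine swaps would remain flat alongside 2-(trifluoromethoxy)phenyl, which appears here only with 4-methylpiperazin-1-yl.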